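Methyl in place of methoxy on the shared core

The source may hold more compounds than are shown below. What is called first, only, known or untested is meant among the compounds shown, and "the series" means these compounds.

compound 1 `COc1ccccc1Nc1nc(-c2cccc(F)c2)nc2ccc(F)cc12` — > 50000 nM, a limit
compound 2 `Oc1ccc(Nc2nc(-c3cccc(F)c3)nc3ccc(F)cc23)cc1` — > 50000 nM, a limit
compound 3 `Nc1cccc(Nc2nc(-c3cccc(F)c3)nc3ccc(F)cc23)c1` — > 50000 nM, a limit

In a functional assay on MDA-MB-231 cells (Homo sapiens) for cytotoxicity, read by MTT assay, with a stated time of 48 h (on this read-out higher numbers stand for weaker inhibition and lower numbers for stronger inhibition), compound 1 gives > 50000 nM, which is a limit of the assay and not a number. Compound 2 gives > 50000 nM, likewise a limit. Compound 3 gives > 50000 nM, again a limit. Compound 1 therefore stands at the common ceiling of the three measured values, (the limit of > 50000 nM in this assay, at which 3 of the 3 values shown sit), and no ordering among them can be read.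

The measured steps are all between limits: a step that the two limits leave unreadable from compound 1 to compound 2, a step that the two limits leave unreadable from compound 1 to compound 3 and a step that the two limits leave unreadable from compound 2 to compound 3. None of them gives a size.

Compound 4 `Cc1ccccc1Nc1nc(-c2cccc(F)c2)nc2ccc(F)cc12` differs from compound 1 by methyl in place of methoxy on an aromatic carbon. The two steps that leave compound 1 replace the whole 2-methoxyphenyl group, whereas here only the methoxy is exchanged for methyl, so neither bears directly on the change, and both would be unreadable even if they did. What the data show is that every variation of the amine-borne aryl group so far has left this assay at its limit.

The step from compound 1 to compound 4 is therefore expected to be a step that the limit leaves unreadable from compound 1 to compound 4, with no direction that the evidence can support. Compound 4 is estimated at 60000 nM, in the range 20000 nM to 200000 nM, and most likely reported only as a limit.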

Compound 4, half-maximal inhibitory concentration: > 50000 nM
Compound 4: no number, only a limit; the forecaster's own chance of this, stated with the estimate: 85%; the middle value lies beyond the limit too.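

In this assay compound 4 gives > 50000 nM, a limit of the assay and not a number. No step between compound 4 and compound 1, compound 2 or compound 3 can be read, as all four stand at one limit: the limit of > 50000 nM in this assay, at which 4 of the 4 values shown sit.

The compounds shown leave open how far methyl and methoxy differ, and whether any aryl group on the nitrogen brings a value under this limit.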